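Moving the Chloro Group Around the Phenyl Ring

The source may hold more compounds than are shown below. What is called first, only, known or untested is meant among the compounds shown, and "the series" means these compounds.

Measured compounds:
- compound 1 `CC1=CC[C@H](C(C)(C)NC(=S)N/N=C/c2ccccc2)CC1`: 71400 nM
- compound 2 `CC1=CC[C@H](C(C)(C)NC(=S)N/N=C/c2ccccc2Cl)CC1`: > 100000 nM

In a functional assay on U-251 cells (Homo sapiens) for inhibition, read by sulforhodamine B assay, with a stated time of 48 h (a higher number here means a weaker inhibitor of growth, a lower number a stronger inhibitor of growth), compound 1 gives 71400 nM. For compound 2, the assay reports only a limit, > 100000 nM, so compound 2 stands at the top edge of what this assay can resolve rather than at a number; the record notes (the limit of > 100000 nM in this assay, at which 1 of the 2 values shown sits).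

Going by the values given here, the only measured step is an at least 1.4-fold higher number from compound 1 to compound 2 (0.14 log units; that floor lies within the scatter), which covers chloro in place of hydrogen on an aromatic carbon. It bears only indirectly on the step now at hand, which is compound 3 `CC1=CC[C@H](C(C)(C)NC(=S)N/N=C/c2cccc(Cl)c2)CC1`, differing from compound 2 by 3-chlorophenyl in place of 2-chlorophenyl on a carbon with a double bond to nitrogen. Among the compounds with values here, no measured pair shows what moving the chlorine around the ring does; the data show only that adding it did not sharpen growth inhibition.

Compound 3 is therefore expected to remain near the limit of this assay, with a fair chance of again being reported only as a limit. The expected step is a number no higher from compound 2 to compound 3 (the limit leaves the size open). The estimate for compound 3 in this assay is 100000 nM, with a range from 30000 nM to 300000 nM.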

Compound 3, concentration for total growth inhibition: 35800 nM
Estimate against measurement, compound 3: 2.8-fold (0.45 log units) above, and the stated range covers the measured number.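

Going by these compounds alone, the place of the chlorine on the phenyl ring matters in this assay: the change shows an at least 2.7-fold lower number from compound 2 to compound 3 (0.44 log units; beyond the scatter), the first step here to clear the scatter, and it comes from a swap in which the same atoms are only joined differently. On these data alone, compound 2 is held at a limit and not at a number, so this step gives a floor and its full size is unknown: the limit of > 100000 nM in this assay, at which 1 of the 3 values shown sits. Adding chlorine at this place does not separate the compound from the one without chlorine, as the comparison gives a 2.0-fold lower number from compound 1 to compound 3 (0.30 log units; within the scatter), so 3-chlorophenyl and plain phenyl cannot be told apart in this assay.

The compounds shown therefore establish a difference between the two chlorophenyl groups but no gain from chlorine over hydrogen, and they leave open how far compound 2 truly lies from compound 1 and from compound 3. They also leave open whether a methoxy group, a nitrile or a bromine on the phenyl ring would give a number that stands clear of compound 1 in this assay.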